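Methoxy to hydroxy on the pyrazole series, compound 4

The compounds below may be only part of what the source reports. "The series", "measured", "known", "first", "only" and "open" are said of these compounds alone.

Working notes. Compound 2 `COc1cc(C)cc(-c2nn(CC#N)cc2-c2ccnc(-c3ccc(N(C)C)cc3)c2)c1` was measured in a functional assay on KM12 cells (Homo sapiens) for cytotoxicity, read by sulforhodamine B assay, with a stated time of 48 h, tested at 100 nM (on this read-out higher numbers stand for a weaker effect at the one concentration tested and lower numbers for a stronger effect), and gives 10%. Of the three numbers in hand this is the second highest. Compound 1 `COc1cc(C)cc(-c2c(-c3ccnc(-c4ccc(N(C)C)cc4)c3)cnn2CC#N)c1` stands nearest: in this assay compound 1 gives -36%, a lower number than compound 2, the gap lying beyond the scatter. Compound 3 `COc1cc(C)cc(-c2nn(CC#N)cc2-c2ccc(-c3cccc(C(C)=O)c3)nc2)c1` stands furthest off: in this assay compound 3 gives 75%, a higher number than compound 2, again beyond the scatter.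

Compound 4 `Cc1cc(O)cc(-c2nn(CC#N)cc2-c2ccnc(-c3ccc(N(C)C)cc3)c2)c1` has not yet been measured. It differs from compound 2 in one place: hydrogen in place of methyl on an oxygen on an aromatic ring. Among the compounds with values here, no pair among the measured compounds shows this change, so nothing in hand tells how far the number should move. Both compounds keep the same nitrile-bearing chain and the same dimethylamino-substituted biaryl arm.

The step expected in this assay is a number 15 percentage points higher from compound 2 to compound 4 (beyond the scatter), most likely a small move toward a higher number, if any beyond the scatter. Compound 4 is therefore estimated at 25%, with a range from -15% to 65%.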

Compound 4, a percentage reported as activity, at one concentration (the size of the read-out at that concentration, not a potency): 66%
Beside the measured number, compound 4's estimate is 41 percentage points below it, outside the stated range (above it).
By their numbers in this assay, from the lowest: compound 1; then compound 2; then compounds 4 and 3 (each within the scatter of the next).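

In this assay, within the data shown here, methoxy to hydroxy on the aromatic ring gives a number 56 percentage points higher from compound 2 to compound 4 (beyond the scatter), the first step that can be read at a single place. The methyl on this oxygen therefore counts for much in this read-out: losing that one carbon, with the rest of the structure unchanged, leaves a much weaker effect at the one concentration tested. Nothing shown accounts for the size of this step.

The compounds shown leave open whether an ethyl group or a longer chain on this oxygen, or an amine in its place, would stay close to compound 2 or move away from it. They also leave open whether the same change would produce a step of similar size on the core of compound 1.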